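This account rests on a few compounds, and the source may have more. Where it says the series, first, only, none or still open, it means among the compounds named here.

Measured compounds:
compound 1 `c1ccc(Nc2ccc(N3CC4CC(C3)N4)cn2)cc1`: 2.66 nM
compound 2 `FC(F)(F)c1ccc(Nc2cncc(N3CC4CC(C3)N4)c2)cc1`: 0.373 nM

In an assay on cell membranes for displacement of a labelled ligand from Neuronal acetylcholine receptor; alpha4/beta2 (Rattus norvegicus) (on this read-out lower numbers stand for stronger inhibition and higher numbers for weaker inhibition), compound 1 gives 2.66 nM, the highest of the two numbers shown. Compound 2 gives 0.373 nM, a lower number well beyond the scatter, but compound 2 also carries a different core, so no single-point comparison with compound 1 is available. Compound 3 `Fc1ccc(Nc2ccc(N3CC4CC(C3)N4)cn2)cc1` differs from compound 1 only by fluoro in place of hydrogen on an aromatic carbon. Without a measured step of this kind, the step is expected to be small, a 1.3-fold lower number from compound 1 to compound 3 (0.12 log units; within the scatter), likely within the scatter or leaning toward a lower number. Compound 3 is therefore estimated at 2 nM, with a range from 0.7 nM to 6 nM.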

Compound 3, inhibition constant: 2.38 nM
For compound 3 the middle estimate is 1.2-fold (0.08 log units) below the measured one; the measured number falls inside the stated range.
By their numbers in this assay, from the lowest: compound 2; then compounds 3 and 1 (each within the scatter of the next).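

In this assay, going by these compounds alone, fluoro in place of hydrogen, para to a large group on the six-membered aromatic ring of carbon only, gives a 1.1-fold lower number from compound 1 to compound 3 (0.05 log units; within the scatter) and thus the first single-place step. On the core of compound 1, phenyl and 4-fluorophenyl therefore read alike within the scatter. No evidence is at hand that explains this result. As far as these compounds go, whether a methoxy group, an amine or a carboxylic acid at this same place would also read alike remains open. From the compounds shown here alone, what separates compound 2 from compound 1 also stays open, since they differ in more than one place.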